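Swapping Chloro for Bromo on a Shared Core

This account rests on a few compounds, and the source may have more. Where it says the series, first, only, none or still open, it means among the compounds named here.

Measured compounds:
Compound 1 `N#CC1=C(N)Oc2cc3oc(-c4ccccc4)cc(=O)c3c(O)c2C12C(=O)N(Cc1ccccc1)c1ccc(Cl)cc12` gives > 50000 nM in a functional assay on PC-3 cells (Homo sapiens) for antiproliferative activity, read by MTT assay, with a stated time of 48 h; on this read-out higher numbers stand for weaker inhibition and lower numbers for stronger inhibition
Compound 2 `N#CC1=C(N)Oc2cc3oc(-c4ccccc4)cc(=O)c3c(O)c2C12C(=O)N(Cc1ccccc1)c1ccc(Br)cc12` gives > 50000 nM in this assay
Compound 3 `N#CC1=C(N)Oc2cc3oc(-c4ccccc4)cc(=O)c3c(O)c2C12C(=O)Nc1cc(Cl)ccc12` gives 25700 nM in this assay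

The values of compound 1 and compound 2 are limits of this assay, not numbers. The step from compound 1 to compound 2 is bromo in place of chloro on an aromatic carbon and a step that the two limits leave unreadable from compound 1 to compound 2, because both sit at the limit of > 50000 nM in this assay, at which 2 of the 3 values shown sit. Within the data shown here, compound 3 is the only one with a number.

Compound 4 `N#CC1=C(N)Oc2cc3oc(-c4ccccc4)cc(=O)c3c(O)c2C12C(=O)Nc1cc(Br)ccc12` is not yet measured; it arises from compound 3 by bromo in place of chloro on an aromatic carbon, the same change as before. The difference between the two cores is not broken down here. With the earlier step unreadable, the expectation rests on compound 3 alone at 25700 nM, and the expected step is a 1.0-fold lower number from compound 3 to compound 4 (0.01 log units; within the scatter). Compound 4 is therefore estimated at 25000 nM, between 10000 nM and 50000 nM.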

Compound 4, half-maximal inhibitory concentration: 24800 nM
Compound 4: the middle estimate sits 1.0-fold (0.00 log units) above what was measured; the range from low to high includes it.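

In this assay, bromo in place of chloro on the core of compound 3 gives a 1.0-fold lower number from compound 3 to compound 4 (0.02 log units; within the scatter), so on this core the two halogens cannot be told apart. The same change on the core of compound 1 cannot be read, because compound 1 and compound 2 both give a limit and not a number: the limit of > 50000 nM in this assay, at which 2 of the 4 values shown sit.

The change can therefore be judged on one core only, and these data do not show whether the result carries over from one core to the other. The compounds shown leave open whether a group other than a halogen on this aromatic carbon, such as an amine or a carboxylic acid, would change the number. They also leave open how either core would respond to such a group.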